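A few compounds are considered here, and "the series" means these few. Any claim that something is new, unique, unknown or untested is made for them only; others in the source may bear on it.

Compound 3 `CC(C)c1onc(-c2c(Cl)cccc2Cl)c1COc1ccc(-c2nc3ccc(C(=O)O)cc3n2C(C)C)cc1` gives the highest of the three numbers in an assay on HEK-293T cells for antagonist activity at vitamin D3 receptor (Homo sapiens), read by a luciferase reporter, with a stated time of 24 h (a higher number here means a weaker inhibitor, a lower number a stronger inhibitor), namely 3550 nM. Its nearest neighbour, compound 2 `CC(C)c1onc(-c2c(Cl)cccc2Cl)c1COc1ccc(-c2nc3ccc(C(=O)O)cc3n2C2CC2)cc1`, gives 3200 nM, and a 1.1-fold higher number from compound 2 to compound 3 (0.05 log units; within the scatter). Compound 1 `CC(C)c1onc(-c2c(Cl)cccc2Cl)c1COc1ccc(-c2nc3ccc(C(=O)O)cc3n2Cc2ccc(F)cc2)cc1`, with 1140 nM, stands furthest away, since a 3.1-fold higher number from compound 1 to compound 3 (0.49 log units; beyond the scatter). Compound 4 `CC(C)c1onc(-c2c(Cl)cccc2Cl)c1COc1ccc(-c2nc3ccc(C(=O)O)cc3n2C2CCCCC2)cc1` has not yet been measured. It differs from compound 3 in one place: cyclohexyl in place of isopropyl on an aromatic nitrogen. The measured steps that bear on this all change the group on the same nitrogen: a 2.8-fold higher number from compound 1 to compound 2 (0.45 log units; beyond the scatter), a 3.1-fold higher number from compound 1 to compound 3 (0.49 log units; beyond the scatter), and a 1.1-fold higher number from compound 2 to compound 3 (0.05 log units; within the scatter). So the 4-fluorobenzyl group gave the lowest number, while the swap between cyclopropyl and isopropyl stayed within the scatter. Whether a cyclohexyl ring behaves like the 4-fluorobenzyl group or like the two smaller alkyls is not settled by these three compounds. For compound 4 a modest move toward a lower number is expected, a 1.8-fold lower number from compound 3 to compound 4 (0.25 log units; within the scatter). A result within the scatter of compound 3 remains plausible. The estimate for compound 4 in this assay is 2000 nM, expected to fall between 800 nM and 5000 nM.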

Compound 4, half-maximal inhibitory concentration: 1450 nM
For compound 4 the middle estimate is 1.4-fold (0.14 log units) above the measured one, and the stated range covers the measured number.
By their numbers in this assay, from the lowest: compounds 1 and 4 (each within the scatter of the next); then compounds 2 and 3 (each within the scatter of the next).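

In this assay, cyclohexyl on the aromatic nitrogen separates from both small alkyl groups, with isopropyl replaced (a 2.4-fold lower number from compound 3 to compound 4 (0.39 log units; beyond the scatter)) and with cyclopropyl replaced (a 2.2-fold lower number from compound 2 to compound 4 (0.34 log units; beyond the scatter)), and both steps lie beyond the scatter. Against 4-fluorobenzyl the same group shows no separation (a 1.3-fold higher number from compound 1 to compound 4 (0.10 log units; within the scatter)), within the scatter, so at this nitrogen a lower number does not require the aromatic ring of that benzyl group, and a non-aromatic ring of six carbons suffices. Nothing available accounts for these differences.

Open, on these data alone, is whether cyclopentyl, or a piperidine ring carrying an amine nitrogen in place of a ring carbon, would track cyclohexyl at this nitrogen. As far as these compounds go, all four compounds keep the carboxylic acid on the shared core, so how an amide there would combine with cyclohexyl also remains open.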